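Nitro in place of hydrogen on the aryl of compound 3

The source may hold more compounds than are shown below. What is called first, only, known or untested is meant among the compounds shown, and "the series" means these compounds.

Of the compounds shown here, three sharing one core have been tested in a functional assay on the whole organism for inhibition, with Mus musculus as the target, in the maximal electroshock model, at a dose of 30 mg/kg by the oral route; on this read-out lower numbers stand for a weaker effect and higher numbers for a stronger effect at the one dose given. Compound 1, `CCC(CO)N1C(=O)NC2(CC2(C)C)C1=O`, gives 90% in this assay. Compound 2, `CC1(C)CC12NC(=O)N(Cc1ccccc1)C2=O`, gives 70%. Compound 3, `CC1(C)CC12NC(=O)N(c1ccccc1)C2=O`, gives 80%. The number for compound 3 lies between the numbers for compound 1 and compound 2, and each of the two gaps around it is within the usual scatter of repeated measurements, so the three compounds cannot be set in order against one another on these data.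

The step now followed leads from compound 3 to compound 4, `CC1(C)CC12NC(=O)N(c1ccc([N+](=O)[O-])cc1)C2=O`. The difference between the two structures is nitro in place of hydrogen on an aromatic carbon. For the measured compounds named here, no pair of measured compounds shows a step of this kind, so nothing measured tells the size of its effect. Since all three measured compounds give high numbers in this assay, the expectation for compound 4 is that the step from compound 3 to compound 4 stays within the scatter, with no clear direction, a number 5 percentage points lower from compound 3 to compound 4 (within the scatter). Compound 4 is therefore estimated to give 75% in this assay, within a range from 45% to 100%.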

Compound 4, a percentage reported as inhibition, in the whole organism at one dose (the size of the read-out at that dose, not a potency): 60%
The estimate for compound 4 lay 15 percentage points above the measured number; the measured number falls inside the stated range.
By their numbers in this assay, from the lowest: compounds 4, 2, 3 and 1 (each within the scatter of the next, the first and the last beyond it).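

In this assay, for the compounds shown here, the aromatic carbon para to a large group on the aryl of compound 3 gives a number 20 percentage points lower from compound 3 to compound 4 (beyond the scatter) as the first readable step in this set, with nitro in place of hydrogen. The earlier compounds shown here offered no pair differing in one place, so they could not show that a change at this carbon moves the number beyond the scatter, and the step now shows that this position does not tolerate every group without loss. The effect is reduced rather than abolished, as compound 4 still gives 60% at the one dose, and no measurement at hand accounts for the drop.

The compounds shown leave open whether an amine, a methoxy group or chlorine on the same carbon would lower the number as well, so this single step cannot separate nitro in particular from any replacement of hydrogen there. Also open, on these data alone, is whether nitro on another carbon of this ring, or on the aromatic ring of compound 2, would give a step of similar size.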